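Aryl hydrazones on two tetrahydrobenzocycloheptene cores

This account rests on a few compounds, and the source may have more. Where it says the series, first, only, none or still open, it means among the compounds named here.

Measured compounds:
compound 1, `O=C(N/N=C/C1=C(Cl)c2ccccc2CCC1)c1cccc(Cl)c1`, 16300 nM
compound 2, `Nc1ccccc1C(=O)N/N=C/C1=C(Cl)c2ccccc2CCC1`, 5000 nM
compound 3, `Cc1cc2c(cc1C)C(Cl)=C(/C=N/NC(=O)c1cccc(Cl)c1)CCC2`, 1930 nM

All three were run in a functional assay on MDA-MB-231 cells (Homo sapiens) for inhibition, read by sulforhodamine B assay, with a stated time of 48 h; a higher number here means a weaker inhibitor of growth, a lower number a stronger inhibitor of growth. Compound 1 and compound 2 share one core; compound 3 carries a different core, and the difference between the two cores is not broken down here. Within the first pair, the change 2-aminophenyl in place of 3-chlorophenyl on a carbonyl carbon gave a 3.3-fold lower number from compound 1 to compound 2 (0.51 log units; beyond the scatter). Compound 3 holds the lowest number of the three, and the unmeasured compound 4, `Cc1cc2c(cc1C)C(Cl)=C(/C=N/NC(=O)c1ccccc1N)CCC2`, applies the same change to its core: 2-aminophenyl in place of 3-chlorophenyl on a carbonyl carbon, at the same place in both pairs. The step from compound 3 to compound 4 is expected to resemble the earlier one, resting only on that single pair, so an estimated 3.0-fold lower number from compound 3 to compound 4 (0.47 log units; beyond the scatter) is carried over. For compound 4 the estimated value in this assay is 650 nM, expected between 250 nM and 2000 nM.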

Compound 4, concentration for 50% growth inhibition: 3700 nM
Compound 4: the middle estimate sits 5.7-fold (0.76 log units) below what was measured; measured number outside the range, above it.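

On the core of compound 3, 2-aminophenyl in place of 3-chlorophenyl gave a 1.9-fold higher number from compound 3 to compound 4 (0.28 log units; within the scatter), so this assay resolves no effect of the change on this core. The lower number seen on the core of compound 1 therefore did not carry over, and the two steps differ: the same change on two cores in this assay, a 3.3-fold lower number (0.51 log units; beyond the scatter) from compound 1 to compound 2 and a 1.9-fold higher number (0.28 log units; within the scatter) from compound 3 to compound 4, 6.2-fold (0.80 log units) apart, beyond the scatter of two such steps

With one pair per core, this shows that the step depends on the core within these four compounds; it does not show why, or how any other core would respond. Which feature of the two cores separates the steps remains open. So does whether another group on the carbonyl carbon, such as a pyridine ring or a longer alkyl chain, would also behave differently on the two cores.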